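Removing a Ring Methyl in a Weakly Cytotoxic Pair

The compounds below may be only part of what the source reports. "The series", "measured", "known", "first", "only" and "open" are said of these compounds alone.

In a functional assay on MCF7 cells (Homo sapiens) for cytotoxicity, read by MTT assay, with a stated time of 48 h (on this read-out higher numbers stand for weaker inhibition and lower numbers for stronger inhibition), compound 1 `Cc1cn([C@@H]2SC[C@@](C)(O)[C@H]2O)c(=O)[nH]c1=O` gives 323000 nM, and its mirror image compound 2 `Cc1cn([C@H]2SC[C@](C)(O)[C@@H]2O)c(=O)[nH]c1=O` gives 172000 nM. For the measured compounds named here, compound 2 thus holds the lower of the two numbers, yet the step of a 1.9-fold lower number from compound 1 to compound 2 (0.27 log units; within the scatter) is within the scatter, so the two compounds cannot be ordered; the only account of this step is the fact that compounds 1 and 2 differ only in the configuration as drawn. Compound 3 `C[C@]1(O)CS[C@H](n2ccc(=O)[nH]c2=O)[C@H]1O` is drawn from compound 2 by hydrogen in place of methyl on an aromatic carbon, a hydrogen in place of methyl on an aromatic carbon, ortho to a group of 1 heavy atom and two atoms from the ring nitrogen. Going by the values given here, no measured step touches this position; the single step known, between mirror images, is within the scatter and does not bear on a change of substituent. For compound 3 the expected step is a 1.2-fold higher number from compound 2 to compound 3 (0.07 log units; within the scatter), within the scatter. The estimate for compound 3 in this assay is 200000 nM, with a range from 70000 nM to 600000 nM.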

Compound 3, half-maximal inhibitory concentration: 100000 nM
For compound 3 the middle estimate is 2.0-fold (0.30 log units) above the measured one, and the stated range covers the measured number.
By their numbers in this assay, from the lowest: compounds 3, 2 and 1 (each within the scatter of the next, the first and the last beyond it).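

In this assay, the position two atoms from the ring nitrogen now has its first measured change, and hydrogen in place of methyl gives a 1.7-fold lower number from compound 2 to compound 3 (0.24 log units; within the scatter). The methyl on this aromatic carbon can therefore be removed from compound 2 without a step beyond the scatter, so this single change leaves no readable effect at this position. For the compounds shown here, the information at hand gives no account of this step, as the only known fact concerns mirror images and not a change of substituent.

The compounds shown leave open whether another group at this position, such as an ethyl group, a bromine atom, an amine or a carboxylic acid, would give a step beyond the scatter. They also leave open whether hydrogen in place of methyl would give a similar step on compound 1, the mirror image of compound 2.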